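Swapping the nitrile end for a tetrazole ring

This account rests on a few compounds, and the source may have more. Where it says the series, first, only, none or still open, it means among the compounds named here.

Compound 3 `CCc1cc(C(C)=O)c(O)cc1OCCCCCCCC(C)(C)C#N` stands second highest of the three numbers measured in an assay on isolated protein for inhibition of leukotriene B4 receptor 1 (Homo sapiens), tested at 10 uM (on this read-out higher numbers stand for more inhibition at the one concentration tested (going by the name of the read-out) and lower numbers for less inhibition), where compound 3 gives 66%. Compound 2 `CCc1cc(C(C)=O)c(O)cc1OCCCCCCC(C)(C)C#N` gives 65%, so the two differ only a number 1 percentage points higher from compound 2 to compound 3 (within the scatter). Compound 1 `CCc1cc(C(C)=O)c(O)cc1OCCCCCCC#N` gives 103%; the drops a number 38 percentage points lower from compound 1 to compound 2 (beyond the scatter) and a number 37 percentage points lower from compound 1 to compound 3 (beyond the scatter) are both large. Compound 4 `CCc1cc(C(C)=O)c(O)cc1OCCCCCC(C)(C)c1nnnn1C` differs from compound 3 in this way: 1-methyl-1-(1-methyl-1H-tetrazol-5-yl)ethyl in place of 3-cyano-3-methylbutyl on a saturated chain carbon, five bonds along the chain from an oxygen on an aromatic ring. Among the measured compounds shown here, no measured step touches a tetrazole, so only indirect guidance exists: the two large drops followed adding branching near the nitrile, while moving the nitrile one carbon further along changed little. Compound 4 is therefore expected to sit near compound 3, a step of a number 8 percentage points lower from compound 3 to compound 4 (within the scatter), estimated at 58% with a range of 32% to 84%.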

Compound 4, a percentage reported as inhibition, at one concentration (the size of the read-out at that concentration, not a potency): 99%
The estimate for compound 4 lay 41 percentage points below the measured number, outside the stated range (above it).
By their numbers in this assay, from the lowest: compounds 2 and 3 (each within the scatter of the next); then compounds 4 and 1 (each within the scatter of the next).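

With the 1-methyl-1-(1-methyl-1H-tetrazol-5-yl)ethyl group on the chain in this assay, the step is a number 33 percentage points higher from compound 3 to compound 4 (beyond the scatter) and likewise a number 34 percentage points higher from compound 2 to compound 4 (beyond the scatter) while the comparison with the unbranched nitrile gives a number 4 percentage points lower from compound 1 to compound 4 (within the scatter) and so no loss remains. A branched chain end therefore does not by itself go with lower inhibition in these four compounds, since compounds 2 and 3 lose inhibition and compound 4 does not. Nothing measured here gives a reason for this difference.

On these data alone, it stays open whether the tetrazole ring needs the branched carbon that carries it. A straight chain ending in the same ring, or a carboxylic acid on that branched carbon, would speak to this.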